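This account rests on a few compounds, and the source may have more. Where it says the series, first, only, none or still open, it means among the compounds named here.

Measured compounds, with their solubility in a physicochemical assay for solubility, read by mass spectrometry, in phosphate buffer, with a stated time of 24 h, at pH 7.4; on this read-out higher numbers stand for higher solubility and lower numbers for lower solubility:
compound 1 `O=C(Nc1ccc(OC(F)(F)F)c(F)c1)NC1CCN(C(=O)C2(C(F)(F)F)CC2)CC1` gives 92 ug/mL
compound 2 `CCOC(=O)N1CCC(NC(=O)Nc2ccc(OC(F)(F)F)c(F)c2)CC1` gives 0.35 ug/mL
compound 3 `O=C(Nc1ccc(OC(F)(F)F)c(F)c1)NC1CCN(C(=O)C2CCCOC2)CC1` gives 174 ug/mL

Compound 1 stands second highest of these three numbers. Its nearest neighbour is compound 3, a step of a 1.9-fold higher number from compound 1 to compound 3 (0.28 log units; within the scatter), which stays within the scatter; its furthest is compound 2, a step of a 260-fold lower number from compound 1 to compound 2 (2.42 log units; beyond the scatter), far beyond the scatter. Between compound 2 and compound 3 the step is a 500-fold higher number from compound 2 to compound 3 (2.70 log units; beyond the scatter).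

The compound still to be measured is compound 4 `O=C(Nc1ccc(C(F)(F)F)c(F)c1)NC1CCN(C(=O)C2(C(F)(F)F)CC2)CC1`. It differs from compound 1 in one place: trifluoromethyl in place of trifluoromethoxy on an aromatic carbon

All three measured steps change the group on the carbonyl carbon attached to the piperidine ring, on the other side of the shared core. Among the measured compounds shown here, none of them touches the aromatic ring where trifluoromethyl replaces trifluoromethoxy, so no measured step bears directly on this change, and there is no evidence here for a large step in this assay in either direction. The expectation is therefore a step within the scatter, estimated as a 1.5-fold lower number from compound 1 to compound 4 (0.19 log units; within the scatter). Compound 4 is estimated to give 60 ug/mL in this assay, with a range from 20 ug/mL to 180 ug/mL.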

Compound 4, solubility: 0.08 ug/mL
Estimate against measurement, compound 4: 750-fold (2.88 log units) above, outside the stated range (below it).
By their numbers in this assay, from the lowest: compound 4; then compound 2; then compounds 1 and 3 (each within the scatter of the next).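

Until now, only changes to the group on the carbonyl carbon had produced large steps in this assay. This result shows that the aromatic carbon ortho to a fluoro group and para to a large group can also produce a large step, even though trifluoromethyl differs from trifluoromethoxy only by the absence of the oxygen: a 1200-fold lower number from compound 1 to compound 4 (3.06 log units; beyond the scatter). No measurement shown here explains why so small an edit to the structure goes with so large a step.

Among the compounds shown here, the exchange is seen only with 1-(trifluoromethyl)cyclopropyl on the carbonyl carbon, so whether it would give a step of similar size with oxan-3-yl or ethoxy there remains an open question. Also open, from the compounds shown here alone, is how other groups on the same aromatic carbon, such as methoxy, a nitrile or an amine, would read in this assay, and with them whether the size of this step is tied to the oxygen itself or is particular to this one pair of compounds.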